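A few compounds are considered here, and "the series" means these few. Any claim that something is new, unique, unknown or untested is made for them only; others in the source may bear on it.

Measured in a functional assay for inhibition, with Homo sapiens as the target; a higher number here means a weaker inhibitor, a lower number a stronger inhibitor:

compound 1 `CC1CCN(c2cccc(Nc3nccc(-c4cccs4)n3)c2)CC1`: 3500 nM
compound 2 `CN(C)c1cccc(Nc2nccc(-c3cccs3)n2)c1`: 2400 nM
compound 3 `CC1CCN(c2ccc(Nc3nccc(-c4cccs4)n3)cc2)CC1`: 400 nM

Compound 1 and compound 2 share one core and differ in a single place: dimethylamino in place of 4-methylpiperidin-1-yl on an aromatic carbon. The step is a 1.5-fold lower number from compound 1 to compound 2 (0.16 log units; within the scatter), so these two numbers cannot be ordered against each other.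

Compound 3 is built from the same atoms as compound 1, joined differently; the difference between the two cores is not broken down here. In this assay compound 3 gives the lowest of the three numbers, and both compound 2 and compound 1 stand beyond the scatter from it.

Compound 4 `CN(C)c1ccc(Nc2nccc(-c3cccs3)n2)cc1` has not yet been measured. It is made from compound 3 by dimethylamino in place of 4-methylpiperidin-1-yl on an aromatic carbon. Among the compounds with values here, this is the same kind of change as the one from compound 1 to compound 2, not the same: around the place, the first sits meta to a large group and the second para to a large group.

The expected step is a 1.3-fold lower number from compound 3 to compound 4 (0.12 log units; within the scatter); this rests on compound 1 and compound 2, where the step of a 1.5-fold lower number from compound 1 to compound 2 (0.16 log units; within the scatter) stayed within the scatter, with the one difference in place noted above left as an open point. Compound 4 is accordingly estimated at 300 nM in this assay, with a range from 120 nM to 800 nM.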

Compound 4, half-maximal inhibitory concentration: 900 nM
Estimate against measurement, compound 4: 3.0-fold (0.48 log units) below; the whole stated range lies below it.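

In this assay, dimethylamino in place of 4-methylpiperidin-1-yl on an aromatic carbon, para to a large group, gives a 2.3-fold higher number from compound 3 to compound 4 (0.35 log units; beyond the scatter), a modest weakening on this core. The change therefore does not carry over as a fixed step, and the reading from the core of compound 1 cannot be transferred directly to the core of compound 3: the same change on two cores in this assay, a 1.5-fold lower number (0.16 log units; within the scatter) from compound 1 to compound 2 and a 2.3-fold higher number (0.35 log units; beyond the scatter) from compound 3 to compound 4, 3.3-fold (0.52 log units) apart, beyond the scatter of two such steps This shows that the effect of the swap depends on the core it is made on, but with one pair per core it does not show what sets the two steps apart, and it gives no rule for predicting the step on any further core.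

The compounds shown leave open how a morpholine, a piperazine or a primary amine would read in the same place on either core, and so whether the step follows the size of the group that enters or something else. A further pair of compounds carrying 4-methylpiperidin-1-yl and dimethylamino on a third core would be needed to tell whether either of the two steps is the more typical one for this series.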